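The compounds below may be only part of what the source reports. "The series", "measured", "known", "first", "only" and "open" are said of these compounds alone.

Measured so far in a functional assay on DU-145 cells (Homo sapiens) for inhibition, read by MTT assay, with a stated time of 24 h; on this read-out higher numbers stand for weaker inhibition and lower numbers for stronger inhibition:

compound 1 `C/C=C(\C)C(=O)O[C@H]1[C@]2(C)C[C@@H]3O[C@@]1(O)C=C1C4=CC(=O)O[C@@H](c5ccoc5)[C@]4(C)CC[C@@H]1[C@]3(C)[C@@H]2[C@@H](O)C(=O)OC`, giving 7700 nM
compound 2 `CCOC(=O)[C@H](O)[C@@H]1[C@@]2(C)C[C@@H]3O[C@@](O)(C=C4C5=CC(=O)O[C@@H](c6ccoc6)[C@]5(C)CC[C@@H]4[C@@]31C)[C@H]2O`, giving 3600 nM

Of the two numbers in hand, compound 2 stands at the lower one; compound 1 gives the higher number, and the gap between them lies beyond the scatter of the read-out. The two compounds differ in more than one place, so nothing is drawn from their pair beyond what the two values show.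

The next compound, compound 3 `COC(=O)[C@H](O)[C@@H]1[C@@]2(C)C[C@@H]3O[C@@](O)(C=C4C5=CC(=O)O[C@@H](c6ccoc6)[C@]5(C)CC[C@@H]4[C@@]31C)[C@H]2O`, keeps the whole of compound 2 apart from one change: hydrogen in place of methyl on a saturated chain carbon bound to an oxygen next to a carbonyl group. For the measured compounds named here, no measured pair in the set carries this change, so its effect is not known here. Given how little is removed, the step from compound 2 to compound 3 is expected to be small, with no direction to prefer, and most likely to fall within the scatter in this assay; the estimated step is a 1.1-fold higher number from compound 2 to compound 3 (0.05 log units; within the scatter). For compound 3 the expected value in this assay is therefore 4000 nM, with a range from 1800 nM to 9000 nM.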

Compound 3, half-maximal inhibitory concentration: > 100000 nM
Compound 3: only a limit was reported (the forecaster's own chance of this, stated with the estimate: 3%); middle value at least 25-fold (1.39 log units) away from the limit.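

In this assay, the ester on the side chain proves far from a silent site: the change from ethoxycarbonyl to methoxycarbonyl, hydrogen in place of methyl on a saturated chain carbon bound to an oxygen next to a carbonyl group, gives an at least 27-fold higher number from compound 2 to compound 3 (1.44 log units; beyond the scatter). The methoxycarbonyl group alone does not account for this loss, since compound 1 carries it too and the change of hydrogen in place of (1-methylprop-1-en-1-yl)carbonyl on an oxygen on a saturated carbon gives an at least 12-fold higher number from compound 1 to compound 3 (1.11 log units; beyond the scatter), so among these three compounds only the one with neither the ethyl ester nor that acyl group falls out of the measurable range. The reading for compound 3 is a limit and not a number, which makes both steps lower bounds: the limit of > 100000 nM in this assay, at which 1 of the 3 values shown sits.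

On these data alone, the true size of each step remains open, as does the outcome of combining the ethoxycarbonyl group with the (1-methylprop-1-en-1-yl)carbonyl group in one compound. Also open, as far as these compounds go, is how a propyl ester, a free carboxylic acid or an amide would behave at the ester, and whether a simple acetyl group on the oxygen would serve as well as the larger acyl group.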